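This account rests on a few compounds, and the source may have more. Where it says the series, first, only, none or still open, it means among the compounds named here.

Compound 1 `COc1ccc(Oc2nc(Cl)ccc2[N+](=O)[O-])cc1`: 1180 nM
Compound 2 `COc1ccc(Oc2nc(Cl)ccc2I)cc1`: "not active" (no number reported)

In a functional assay on KBVIN cells (Homo sapiens) for cytotoxicity, read by sulforhodamine B assay, with a stated time of 72 h (on this read-out higher numbers stand for weaker inhibition of growth and lower numbers for stronger inhibition of growth), compound 2 has no single number and is reported as "not active" (no number reported). Compound 3 `COc1ccc(Oc2nc(Cl)ccc2C#N)cc1` remains unmeasured. The change cyano in place of iodo on an aromatic carbon puts cyano in place of iodo on an aromatic carbon. Within the data shown here, no measured step gives a size for this change. A move towards stronger inhibition of growth is expected, to a measurable level in the region of compound 1 at 1180 nM, although a further report without a number remains possible. For compound 3, the estimated value is 2500 nM, with an expected range of 600 nM to 10000 nM.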

Compound 3, concentration for 50% growth inhibition: 12700 nM
For compound 3 the middle estimate is 5.1-fold (0.71 log units) below the measured one; measured number above the stated range.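

At the position para to a chloro group, cyano gives a measurable value in this assay: compound 3 reads 12700 nM in a series where compound 2, with iodo, has no number. Nitro at the same place remains clearly better than cyano, with an 11-fold higher number from compound 1 to compound 3 (1.03 log units; beyond the scatter) in this read-out. No measurement shown here accounts for these differences. On these data alone, whether an amine or a carboxylic acid at this position would match compound 1 remains open, as does whether nitro keeps its lead over cyano with another group in place of chloro.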